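Dimethylamino in Place of Methylsulfamoyl on the Side Chain

The source may hold more compounds than are shown below. What is called first, only, known or untested is meant among the compounds shown, and "the series" means these compounds.

Of the compounds shown here, three sharing one core have been tested in a functional assay on the whole organism with Rattus norvegicus as the target; a higher number here means that more compound is needed for the effect, a lower number that less compound is needed. Compound 1 `C[Si](C)(C)c1ccc2nc(N)sc2c1` gives 5 mg/kg. Compound 2 `CC(C)c1ccc2nc(N)sc2c1` reaches only a limit of the assay, > 10 mg/kg, so no number is known for it. For the measured compounds named here, the one step between measured compounds, an at least 2.0-fold higher number from compound 1 to compound 2 (0.30 log units; that floor lies within the scatter), rests on that limit (the limit of > 10 mg/kg in this assay, at which 1 of the 3 values shown sits). Compound 3 `CNS(=O)(=O)CCn1c(=N)sc2cc(OC(F)(F)F)ccc21` gives 4 mg/kg, which lies within the scatter of the value of compound 1.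

Compound 4 `CN(C)CCn1c(=N)sc2cc(OC(F)(F)F)ccc21` differs from compound 3 in one place: dimethylamino in place of methylsulfamoyl on a saturated chain carbon, two bonds along the chain from an aromatic nitrogen. No measured step touches this change; the single step shown concerns a group on an aromatic carbon of the core and says nothing about the saturated chain. With nothing measured bearing on the change, the expected step of no change at the digits printed from compound 3 to compound 4 (within the scatter) is none beyond the scatter. Compound 4 is therefore estimated in this assay at 4 mg/kg, with a range from 1.5 mg/kg to 12 mg/kg.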

Compound 4, dose for half-maximal effect: 2.3 mg/kg
Estimate against measurement, compound 4: 1.7-fold (0.24 log units) above; low and high end bracket the measured number.
By their numbers in this assay, from the lowest: compounds 4, 3 and 1 (each within the scatter of the next, the first and the last beyond it). At a limit, above all of these: compound 2.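

For the compounds shown here, the earlier compounds said nothing about the saturated chain, since their one step concerns a group on an aromatic carbon of the core. Going by these compounds alone, this pair is the first to probe the chain: replacing methylsulfamoyl with dimethylamino gives a 1.7-fold lower number from compound 3 to compound 4 (0.24 log units; within the scatter) in this assay, although the entering group has fewer heavy atoms and no hydrogen-bond donor. At this place, then, these two quite different groups cannot be told apart in this assay, and nothing in the data shown explains that result.

This is a single pair, so it sets no trend for the position. Open questions are whether a carboxylic acid, a primary amine or a longer chain in place of 2-(dimethylamino)ethyl would also leave the number within the scatter, and whether a ring-bearing amine would do the same.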